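This account rests on a few compounds, and the source may have more. Where it says the series, first, only, none or still open, it means among the compounds named here.

Compound 1 `CCCOc1ccc(C(=O)NNc2c(Br)cccc2Br)cc1`: > 100000 nM
Compound 2 `CC(C)(C)c1ccc(C(=O)NNc2c(Br)cccc2Br)cc1`: > 100000 nM
Compound 3 `N#Cc1ccc(C(=O)NNc2c(Br)cccc2Br)cc1`: > 100000 nM

All three entries come from a toxicity assay on MDCK cells (Canis lupus familiaris) for cytotoxicity, read by CCK-8 assay, with a stated time of 48 h; a lower number here means that less compound is tolerated, a higher number that more compound is tolerated. Compound 3 gives > 100000 nM, and this is a limit of the assay, not a number. Going by the values given here, it therefore has no exact place among the compounds measured so far, and the whole series shares one reading: the limit of > 100000 nM in this assay, at which 3 of the 3 values shown sit.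

Compound 4 `COC(=O)c1ccc(C(=O)NNc2c(Br)cccc2Br)cc1` keeps the shared core and differs from compound 3 in one group. It has methoxycarbonyl in place of cyano, on an aromatic carbon para to a large group (methoxycarbonyl in place of cyano on an aromatic carbon).

Three measured steps also exchange a single group on an aromatic carbon: a step that the two limits leave unreadable from compound 1 to compound 2, then a step that the two limits leave unreadable from compound 1 to compound 3, and finally a step that the two limits leave unreadable from compound 2 to compound 3. None of them offers a size to carry over. Since a step that the two limits leave unreadable from compound 2 to compound 3 gives no readable size either, no step beyond the scatter is expected in this assay, and the most likely report is another limit. The expected step is a number no higher from compound 3 to compound 4 (the limit leaves the size open). Compound 4 is estimated at 100000 nM, with an expected range from 50000 nM to 200000 nM.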

Compound 4, half-maximal cytotoxic concentration: 87600 nM
For compound 4 the middle estimate is 1.1-fold (0.06 log units) above the measured one; low and high end bracket the measured number.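

In this assay, going by these compounds alone, compound 4 is the first compound of the series to give a number and not a limit, so this position, para to a large group, now has one exact reading. Methoxycarbonyl in place of cyano is an at least 1.1-fold lower number from compound 3 to compound 4 (0.05 log units; that floor lies within the scatter), methoxycarbonyl in place of tert-butyl is an at least 1.1-fold lower number from compound 2 to compound 4 (0.05 log units; that floor lies within the scatter), and methoxycarbonyl in place of propoxy is an at least 1.1-fold lower number from compound 1 to compound 4 (0.05 log units; that floor lies within the scatter). Each of these steps is only a floor, so the exchange may matter little or a great deal, and most of the series still shares a single reading: the limit of > 100000 nM in this assay, at which 3 of the 4 values shown sit.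

From the compounds shown here alone, the steps among compounds 1, 2 and 3 cannot be read, and how far those three compounds lie past their limits stays unknown, so no order among the four compounds can be drawn. Also open, going by these compounds, is whether an amine, a carboxylic acid or a longer chain on this aromatic carbon would give a number, as methoxycarbonyl does in compound 4, or another limit.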